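Moving the chlorine on a GABA-B modulator phenyl ring

A few compounds are considered here, and "the series" means these few. Any claim that something is new, unique, unknown or untested is made for them only; others in the source may bear on it.

Measured compounds:
compound 1 `Cc1nc(N[C@@H]2C[C@H]3CC[C@@H]2C3)c2cc(-c3ccc(C(F)(F)F)cc3)ccc2n1`: 771 nM
compound 2 `Cc1nc(N[C@@H]2C[C@H]3CC[C@@H]2C3)c2cc(-c3ccc(Cl)cc3)ccc2n1`: 444 nM

In a functional assay for positive allosteric modulation of GABA-B receptor (Homo sapiens), read by GTPgammaS binding (a higher number here means that more compound is needed for the effect, a lower number that less compound is needed), compound 1 gives 771 nM. Going by the values given here, compound 2 gives 444 nM, the lowest of the two numbers, and the one step among them is a 1.7-fold lower number from compound 1 to compound 2 (0.24 log units; within the scatter), which lies within the scatter.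

Compound 3 `Cc1nc(N[C@@H]2C[C@H]3CC[C@@H]2C3)c2cc(-c3cccc(Cl)c3)ccc2n1` differs from compound 2 by 3-chlorophenyl in place of 4-chlorophenyl on an aromatic carbon. Among the compounds with values here, no measured step bears on shifting a chlorine around its ring; the only step swapped one group for another without moving it. With nothing pointing either way, the expected step is a 1.1-fold higher number from compound 2 to compound 3 (0.05 log units; within the scatter), none beyond the scatter. Compound 3 is therefore estimated at 500 nM, within a range from 180 nM to 1400 nM.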

Compound 3, half-maximal effective concentration: 199 nM
For compound 3 the middle estimate is 2.5-fold (0.40 log units) above the measured one; low and high end bracket the measured number.
By their numbers in this assay, from the lowest: compound 3; then compounds 2 and 1 (each within the scatter of the next).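

In this assay moving the chlorine from 4-chlorophenyl to 3-chlorophenyl gives a 2.2-fold lower number from compound 2 to compound 3 (0.35 log units; beyond the scatter) and so shows that, with the same atoms, where the chlorine sits on this ring can matter. Going by these compounds alone, the earlier swap of trifluoromethyl for chloro stayed within the scatter, so this is the first step here to go beyond it. Nothing available explains why the chlorine's position matters. As far as these compounds go, whether trifluoromethyl would shift the same way on moving stays open, as does whether a nitrile or a methoxy group would follow chlorine on this ring.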